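Removing the cyclopropylethynyl arm from compound 2

The source may hold more compounds than are shown below. What is called first, only, known or untested is meant among the compounds shown, and "the series" means these compounds.

Measured compounds:
Compound 1, `CCCCCCc1cc2cn(Cc3cn(Cc4ccccc4)nn3)c(=O)nc2o1`: 93500 nM
Compound 2, `O=c1nc2oc(C3CC3)c(C#CC3CC3)c2cn1Cc1cn(Cc2ccccc2)nn1`: 9720 nM
Compound 3, `O=c1nc2oc(C3CC3)c(C#CC3CC3)c2cn1Cc1cn(-c2ccccc2F)nn1`: 49100 nM

In a functional assay on SW-620 cells (Homo sapiens) for antiproliferative activity, read by MTT assay, with a stated time of 72 h (on this read-out lower numbers stand for stronger inhibition and higher numbers for weaker inhibition), compound 2 gives the lowest of the three numbers. Its nearest neighbour is compound 3, and the step of a 5.1-fold higher number from compound 2 to compound 3 (0.70 log units; beyond the scatter) lies beyond the scatter. Among the compounds with values here, compound 1 stands furthest away, with 93500 nM against 9720 nM for compound 2; compound 1 differs from compound 2 in more than one place, so no single step is drawn between them.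

The unmeasured compound 4, `O=c1nc2oc(C3CC3)cc2cn1Cc1cn(Cc2ccccc2)nn1`, is compound 2 with one change: hydrogen in place of 2-cyclopropylethynyl on an aromatic carbon.

Within the data shown here, none of the measured steps touches this position. Among the measured compounds shown here, the only step in hand, from compound 2 to compound 3, concerns the group on the aromatic nitrogen and says nothing about the cyclopropylethynyl group. What the numbers do show is that the two compounds carrying the cyclopropylethynyl group, compound 2 and compound 3, give the two lower values, while compound 1, which lacks it, gives the highest; but compound 1 also carries a different group at the neighbouring position, so this is only a hint. Compound 4 is therefore expected to give a modestly higher number, a 3.1-fold higher number from compound 2 to compound 4 (0.49 log units; beyond the scatter), with a wide range. The estimate for compound 4 in this assay is 30000 nM, between 8000 nM and 120000 nM.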

Compound 4, half-maximal inhibitory concentration: 54700 nM
Beside the measured number, compound 4's estimate is 1.8-fold (0.26 log units) below it; measured number inside the range.
By their numbers in this assay, from the lowest: compound 2; then compounds 3, 4 and 1 (each within the scatter of the next).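

Taking away the 2-cyclopropylethynyl group and leaving hydrogen on that aromatic carbon gives in this assay the first step read at this position: a 5.6-fold higher number from compound 2 to compound 4 (0.75 log units; beyond the scatter) and thus a modest change, but one beyond the scatter. With that group gone, exchanging hexyl for cyclopropyl gives a 1.7-fold lower number from compound 1 to compound 4 (0.23 log units; within the scatter) and leaves compound 1 and compound 4 indistinguishable. The earlier hint therefore rests on firmer ground, as the direct step ties the loss to the missing 2-cyclopropylethynyl group, while hexyl against cyclopropyl on an aromatic carbon shows no change beyond the scatter in this pair.

Still open, going by these compounds, is whether the triple bond or the three-membered ring carries the step, whether a plain ethynyl, a methyl or a phenylethynyl group on this carbon would hold the number of compound 2, and whether the same loss would appear alongside the 2-fluorophenyl group of compound 3. Nothing at hand offers an explanation for the step.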